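Swapping an aromatic ring for a non-aromatic one in compound 3

A few compounds are considered here, and "the series" means these few. Any claim that something is new, unique, unknown or untested is made for them only; others in the source may bear on it.

Of the compounds shown here, two sharing one core have been measured. Compound 1 `C[C@@H](O[C@H]1CN2C(=O)C=C(c3cc[n+]([O-])cc3)CC2[C@@H]1c1ccc(F)cc1)c1cc(C(F)(F)F)cc(C(F)(F)F)c1` gives 0.1 nM in an assay on CHO cells for displacement of a labelled ligand from Substance-P receptor (Homo sapiens) (a higher number here means a weaker inhibitor, a lower number a stronger inhibitor), and compound 2 `C[C@@H](O[C@H]1CN2C(=O)C=C(c3ccc[n+]([O-])c3)CC2[C@@H]1c1ccc(F)cc1)c1cc(C(F)(F)F)cc(C(F)(F)F)c1` gives 0.15 nM in this assay. Among the measured compounds shown here, the only step between them, a 1.5-fold higher number from compound 1 to compound 2 (0.18 log units; within the scatter), leaves the two within the scatter of each other, so compound 2 stands alongside compound 1 with no real separation between them.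

Compound 3 `C[C@@H](O[C@H]1CN2C(=O)C=C(C3=CCOCC3)CC2[C@@H]1c1ccc(F)cc1)c1cc(C(F)(F)F)cc(C(F)(F)F)c1` carries a different change: a group of 6 heavy atoms (5 carbon, 1 oxygen; one six-membered non-aromatic ring with 1 hetero atom) in place of a group of 7 heavy atoms (5 carbon, 1 nitrogen, 1 oxygen; one six-membered aromatic ring with 1 hetero atom), on a double-bonded ring carbon. The measured step compared two aromatic rings of the same kind, differing only in where the hetero atom sits, and it barely moved the number. Here the ring that enters is non-aromatic, with an oxygen in place of the nitrogen-oxygen pair, so no measured step speaks directly to it. A small loss in this assay is expected for compound 3, on the order of a 2.0-fold higher number from compound 2 to compound 3 (0.30 log units; within the scatter), though a result within the scatter of compound 2 would not surprise. The expected value for compound 3 is 0.3 nM, within a range from 0.08 nM to 1.5 nM.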

Compound 3, half-maximal inhibitory concentration: 0.18 nM
Estimate against measurement, compound 3: 1.7-fold (0.22 log units) above; the range from low to high includes it.
By their numbers in this assay, from the lowest: compounds 1, 2 and 3 (each within the scatter of the next).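

In this assay, replacing the aromatic ring of compound 2 with the six-membered non-aromatic ring gives a 1.2-fold higher number from compound 2 to compound 3 (0.08 log units; within the scatter), and the same comparison with compound 1 gives a 1.8-fold higher number from compound 1 to compound 3 (0.26 log units; within the scatter). The earlier step showed only that the hetero atom of the aromatic ring could sit in a different place, whereas these steps show that, across these three compounds, this double-bonded ring carbon can carry a non-aromatic ring with an oxygen, and one double bond outside aromatic rings, without leaving the scatter of the two aromatic compounds. No measurement is available here that explains this result.

Going by these compounds, all three groups at this carbon are six-membered rings with one hetero atom, so it remains open whether the number would hold with a fully saturated ring, a ring amine such as piperidine, a carboxylic acid or a short open chain such as ethyl. With a single assay shown, it also remains open whether these three compounds would stay this close in any other measurement.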